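The compounds below may be only part of what the source reports. "The series", "measured", "known", "first", "only" and "open" are said of these compounds alone.

Of the compounds shown here, three that share one core have numbers so far in a functional assay on SK-MEL-5 cells (Homo sapiens) for inhibition; on this read-out higher numbers stand for weaker inhibition of growth and lower numbers for stronger inhibition of growth. In that assay compound 1 `CN(C)c1ccc(NS(=O)(=O)c2c(F)c(F)c(F)c(F)c2F)cc1` gives 183 nM, and compound 2 `Cc1ccc(NS(=O)(=O)c2c(F)c(F)c(F)c(F)c2F)cc1C` gives 151 nM; these two values lie within the scatter of each other. Compound 3 `O=S(=O)(Nc1ccc2c(c1)OCCO2)c1c(F)c(F)c(F)c(F)c1F` gives 20 nM, a number beyond the scatter from compound 1 and one that stands for stronger inhibition of growth. Compound 1 therefore sits at the upper end of this small set, level with compound 2.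

The next compound, compound 4 `COc1ccc(NS(=O)(=O)c2c(F)c(F)c(F)c(F)c2F)cc1`, keeps the core of compound 1 and changes one group: methoxy in place of dimethylamino on an aromatic carbon, para to a large group (methoxy in place of dimethylamino on an aromatic carbon). Going by the values given here, no measured pair shows this exact change, so there is no direct guide. The other values only show the range open so far: compound 2 stays level at 151 nM, while compound 3 reaches 20 nM. A guess inside that range points to a modest move toward stronger inhibition of growth. The expected step is a 2.0-fold lower number from compound 1 to compound 4 (0.31 log units; beyond the scatter), an estimate that stays near the edge of the scatter. For compound 4 the estimated value is 90 nM, with an expected range from 30 nM to 250 nM.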

Compound 4, concentration for 50% growth inhibition: < 10 nM
Compound 4: only a limit was reported (the forecaster's own chance of this, stated with the estimate: 2%); at least 9.0-fold (0.95 log units) between middle value and limit.
By their numbers in this assay, from the lowest: compound 3; then compounds 2 and 1 (each within the scatter of the next). At a limit, below all of these: compound 4.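

Going by these compounds alone, at this position, on an aromatic carbon para to a large group, the exchange of dimethylamino for methoxy gives an at least 18-fold lower number from compound 1 to compound 4 (1.26 log units; beyond the scatter), the first evidence that this single group strongly affects the number, as the earlier compounds, with no step between them, could not show. In this assay compound 4 is reported only as a limit, < 10 nM. The full size of the step therefore stays unknown because the reading for compound 4 stops at a limit, so the step gives only the smallest gap the data support: the limit of < 10 nM in this assay, at which 1 of the 4 values shown sits.

The two groups match in their counts of hydrogen-bond donors and acceptors, have no ring and carry no net charge, and they differ by a single heavy atom, so these counts alone do not explain the large step, and the compounds shown do not reveal what does. Going by these compounds, it also remains open how an ethoxy group, a hydroxyl group or a plain primary amine at this same position would read, and so whether the result is particular to methoxy or extends to other small groups.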